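The source may report more compounds than this note shows. Statements on the series, on what has been measured and on what is new or still open speak of the compounds shown alone.

Going by the values given here, compound 2 `O=[N+]([O-])c1ccc(CSc2nc(NC3CCC3)nc3c2ncn3[C@@H]2O[C@H](CO)[C@@H](O)[C@H]2O)cc1` gives 33 nM in an assay on K562 cells for displacement of a labelled ligand from Equilibrative nucleoside transporter 1 (Homo sapiens), read by flow cytometry, with a stated time of 45 min (a lower number here means a stronger inhibitor, a higher number a weaker inhibitor), the lowest of the two numbers so far, while compound 1 `CCCNc1nc(SCc2ccc([N+](=O)[O-])cc2)c2ncn([C@@H]3O[C@H](CO)[C@@H](O)[C@H]3O)c2n1` gives 193 nM in this assay. Among the compounds with values here, the single measured step, a 5.8-fold lower number from compound 1 to compound 2 (0.77 log units; beyond the scatter), shows how much the group on that nitrogen moves the number. Compound 3 `O=[N+]([O-])c1ccc(CSc2nc(NCCO)nc3c2ncn3[C@@H]2O[C@H](CO)[C@@H](O)[C@H]2O)cc1` carries 2-hydroxyethyl in place of cyclobutyl on a nitrogen on an aromatic ring. Within the data shown here, only that one step bears on the change, and the move away from cyclobutyl in this case points toward a higher number, so a modest rise is expected, a 9.1-fold higher number from compound 2 to compound 3 (0.96 log units; beyond the scatter). Compound 3 is expected to give about 300 nM, within 80 nM to 1200 nM.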

Compound 3, inhibition constant: 86 nM
For compound 3 the middle estimate is 3.5-fold (0.54 log units) above the measured one; the range from low to high includes it.
By their numbers in this assay, from the lowest: compound 2; then compound 3; then compound 1.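

In this assay, leaving cyclobutyl for 2-hydroxyethyl on this nitrogen gives a 2.6-fold higher number from compound 2 to compound 3 (0.42 log units; beyond the scatter), so compound 2 keeps the lowest number of the three. Yet an open chain here is not tied to one level: hydroxy in place of methyl on the saturated chain carbon gives a 2.2-fold lower number from compound 1 to compound 3 (0.35 log units; beyond the scatter). Nothing shown explains either step. The compounds shown leave open whether an amine or a carboxylic acid in place of that hydroxy would lower the number further. They also leave open how a cyclopropyl or cyclopentyl ring on this nitrogen would compare with cyclobutyl.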